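Aryl para substituent swap: ethoxy replaced by cyano

This account rests on a few compounds, and the source may have more. Where it says the series, first, only, none or still open, it means among the compounds named here.

Values to date in an assay on CHO cells for displacement of a labelled ligand from corticotropin-releasing factor receptor 1 (Homo sapiens); a higher number here means a weaker inhibitor, a lower number a stronger inhibitor:
compound 1 `COc1ccc(N2CCc3c(-n4ccc(N5CCNC5=O)n4)cc(C)nc32)c(C(F)F)c1`: 56.2 nM
compound 2 `COc1ccc(N2CCc3c(-n4ccc(N5CCNS5(=O)=O)n4)cc(C)nc32)c(C)c1`: 309 nM
compound 3 `CCOc1ccc(N2CCc3c(-n4ccc(N5CCNC5=O)n4)cc(C)nc32)c(C)c1`: 316 nM

Compound 3 carries the largest of the three numbers, but its gap to compound 2 is within the scatter, so the two cannot be told apart on this assay. Only compound 1 sits clearly lower, beyond the scatter from compound 3. Compound 1 and compound 3 differ in two places at once, so their pair gives no clean read on any single change.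

Compound 4 `Cc1cc(-n2ccc(N3CCNC3=O)n2)c2c(n1)N(c1ccc(C#N)cc1C)CC2` is the next point. Relative to compound 3 the change is cyano in place of ethoxy on an aromatic carbon. Among the measured compounds shown here, no measured pair isolates this swap, so the expectation rests on the spread seen so far: the three measured compounds span a range that is beyond the scatter only between compound 1 and the other two. A modest step is expected here, most likely toward a somewhat lower number, though a step within the scatter in either direction would not surprise. The step from compound 3 to compound 4 is estimated at a 1.8-fold lower number from compound 3 to compound 4 (0.24 log units; within the scatter). For compound 4 the expected value in this assay is 180 nM, with a plausible range from 50 nM to 650 nM.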

Compound 4, half-maximal inhibitory concentration: 67.6 nM
Beside the measured number, compound 4's estimate is 2.7-fold (0.43 log units) above it, within the range that was stated.
By their numbers in this assay, from the lowest: compounds 1 and 4 (each within the scatter of the next); then compounds 2 and 3 (each within the scatter of the next).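

In this assay, among the compounds shown here, the change from 4-ethoxy-2-methylphenyl to 4-cyano-2-methylphenyl gives a 4.7-fold lower number from compound 3 to compound 4 (0.67 log units; beyond the scatter), the first step that isolates a single place. It shows that the substituent on this aromatic carbon, para to a large group and meta to the methyl group, matters to the read-out: replacing ethoxy with cyano moves the number beyond the scatter, with the rest of the structure unchanged. No measurement shown here accounts for the size or direction of this step.

Compound 1 and compound 2 carry methoxy at this position, but each also differs from compound 3 and compound 4 elsewhere, so methoxy cannot yet be placed relative to ethoxy or cyano. For the compounds shown here, with only this one pair to go on, it remains open whether the lower number belongs to cyano specifically or would also appear with a chlorine, a primary amide or a bare hydrogen at this carbon, and whether the step carries over when other parts of the structure change.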